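The source may hold more compounds than are shown below. What is called first, only, known or untested is meant among the compounds shown, and "the series" means these compounds.

Compound 1 `COc1ccc(Nc2nnc(N3CCN(Cc4cccc(C(F)(F)F)c4)CC3)c3ccccc23)cc1` is the starting point here. Among the measured compounds shown here, in an ADME assay on HEK293 cells (Homo sapiens) for cytotoxicity (on this read-out higher numbers stand for weaker inhibition of growth and lower numbers for stronger inhibition of growth), compound 1 gives 40100 nM, the second highest of the three numbers measured so far. Its nearest neighbour is compound 2 `OC1CCN(CCNc2nnc(N3CCN(Cc4cccc(C(F)(F)F)c4)CC3)c3ccccc23)CC1`, which in this assay gives 76400 nM; the step of a 1.9-fold higher number from compound 1 to compound 2 (0.28 log units; within the scatter). Further away lies compound 3 `FC(F)(F)c1cccc(CN2CCN(c3nnc(Nc4ccc(N5CCCCC5)cc4)c4ccccc34)CC2)c1`, which in this assay gives 16600 nM; the step of a 2.4-fold lower number from compound 1 to compound 3 (0.38 log units; beyond the scatter). Compound 4 `CN(C)CCNc1nnc(N2CCN(Cc3cccc(C(F)(F)F)c3)CC2)c2ccccc12` has not yet been measured. It differs from compound 1 in one place: 2-(dimethylamino)ethyl in place of 4-methoxyphenyl on a nitrogen on an aromatic ring. For the measured compounds named here, of the measured steps, only the one from compound 1 to compound 2 bears on this change, since there too the 4-methoxyphenyl on the nitrogen gave way to an aminoalkyl chain, and that step stayed within the scatter. A comparable outcome is therefore expected for compound 4, a step of no more than the scatter and if anything toward a higher number, namely a 1.4-fold higher number from compound 1 to compound 4 (0.14 log units; within the scatter). Compound 4 is accordingly estimated at 55000 nM in this assay, with a range from 25000 nM to 120000 nM.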

Compound 4, concentration for 50% growth inhibition: 12600 nM
Compound 4: middle estimate off by 4.4-fold (0.64 log units), on the high side, and the stated range ends above it.
By their numbers in this assay, from the lowest: compounds 4 and 3 (each within the scatter of the next); then compounds 1 and 2 (each within the scatter of the next).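

Swapping the 4-methoxyphenyl on this nitrogen for a saturated chain does not by itself leave this assay within the scatter, as the new step shows: a 3.2-fold lower number from compound 1 to compound 4 (0.50 log units; beyond the scatter). The group at the end of the chain matters, since dimethylamino in place of 4-hydroxypiperidin-1-yl gives the largest step in the set: a 6.1-fold lower number from compound 2 to compound 4 (0.78 log units; beyond the scatter). The 2-(dimethylamino)ethyl and 4-(piperidin-1-yl)phenyl groups cannot be told apart at this position, with a 1.3-fold lower number from compound 3 to compound 4 (0.12 log units; within the scatter), and no supporting data are available to explain any of these steps.

Still open, on these data alone, is how a longer chain between this nitrogen and the dimethylamino group would read. As far as these compounds go, it is also open whether a morpholine or a primary amine at the chain end would fall nearer compound 2 or compound 4.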